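A few compounds are considered here, and "the series" means these few. Any claim that something is new, unique, unknown or untested is made for them only; others in the source may bear on it.

Compound 1 `Nc1nc(NC2CCCCC2)c2ncn(/C=C3/CC3(CO)CO)c2n1` carries a cyclohexylamino group on an aromatic carbon of its core. In an ADME assay on BCBL1 cells (Homo sapiens) for cytotoxicity, with a stated time of 7 days (a higher number here means that more compound is tolerated, a lower number that less compound is tolerated), compound 1 gives > 20000 nM, which is a limit of the assay rather than a number. Compound 2 `CCCOc1nc(N)nc2c1ncn2/C=C1/CC1(CO)CO` carries propoxy in the same position, and in this assay compound 2 gives > 20000 nM, again a limit. Compound 3 `Nc1nc(OCc2ccccc2)c2ncn(/C=C3/CC3(CO)CO)c2n1` carries benzyloxy, and compound 3 gives > 20000 nM, also a limit.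

The measured steps are therefore a step that the two limits leave unreadable from compound 1 to compound 2 and a step that the two limits leave unreadable from compound 1 to compound 3, together with a step that the two limits leave unreadable from compound 2 to compound 3. All three values sit at the same point because of the limit of > 20000 nM in this assay, at which 3 of the 3 values shown sit, so none of these steps reveals a direction or a size.

Compound 4 `CCCCOc1nc(N)nc2c1ncn2/C=C1/CC1(CO)CO` differs from compound 1 in one place: butoxy in place of cyclohexylamino on an aromatic carbon. Compounds 2 and 3 show that replacing cyclohexylamino by an alkoxy or aralkoxy group leaves the read-out at the limit, and butoxy in compound 4 is a change of the same kind. No measurable step beyond the scatter is therefore expected; the expected step is a step that the limit leaves unreadable from compound 1 to compound 4. Compound 4 is estimated at 30000 nM, within a range from 15000 nM to 80000 nM, most likely reported again only as a limit.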

Compound 4, half-maximal cytotoxic concentration: > 20000 nM
Compound 4: only a limit was reported; the forecaster's own chance of this, stated with the estimate: 85%; the middle value lies beyond the limit too.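

Compound 4 is reported only as a limit in this assay, so its steps to compound 1, compound 2 and compound 3 cannot be read: the limit of > 20000 nM in this assay, at which 4 of the 4 values shown sit.

The compounds shown leave open whether cyclohexylamino, propoxy, benzyloxy and butoxy on the shared core differ at all in this assay, and at what concentration any of the four stops being tolerated.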